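The compounds below may be only part of what the source reports. "The series", "measured", "known", "first", "only" and "open" are said of these compounds alone.

Measured in a functional assay on NCI-H460 cells (Homo sapiens) for cytotoxicity, read by sulforhodamine B assay, with a stated time of 48 h; on this read-out lower numbers stand for stronger inhibition of growth and higher numbers for weaker inhibition of growth:

compound 1 `ClCc1ccc(Cn2cnc3c(Cl)ncnc32)cc1` — 1820 nM
compound 2 `Nc1nc(Cl)c2ncn(Cc3ccc(CCl)cc3)c2n1` — 9950 nM
compound 3 `ClCc1ccccc1Cn1cnc2c(Cl)ncnc21` — 44700 nM

The series rests on one core with a chloromethyl-bearing benzyl group attached to it. Compound 1 and compound 3 have the same atoms, joined differently; the difference between the two cores is not broken down here. In this assay compound 3 is the weakest of the three measured compounds, its value lying furthest from that of compound 1 and nearest to that of compound 2, both gaps being beyond the scatter.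

One change is seen twice among the compounds here: amino in place of hydrogen on an aromatic carbon. Made on the core of compound 1 it gives compound 2, and the step of a 5.5-fold higher number from compound 1 to compound 2 (0.74 log units; beyond the scatter) stands as the only measured instance.

Compound 4 `Nc1nc(Cl)c2ncn(Cc3ccccc3CCl)c2n1` has not yet been measured in this assay. It arises from compound 3 by amino in place of hydrogen on an aromatic carbon, and the place description matches that of the change from compound 1 to compound 2 word for word, so it is the same change on a differently joined core.

The expectation for compound 4 is a step of a 4.0-fold higher number from compound 3 to compound 4 (0.60 log units; beyond the scatter), estimated to be of a size close to the one seen in a 5.5-fold higher number from compound 1 to compound 2 (0.74 log units; beyond the scatter) because compound 3 already stands at 44700 nM and the change has weakened growth inhibition once. Compound 4 is thus estimated at 180000 nM in this assay, with a range from 60000 nM to 500000 nM; a value so high may be reported only as a limit.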

Compound 4, concentration for total growth inhibition: 37200 nM
Compound 4: the middle estimate sits 4.8-fold (0.68 log units) above what was measured; measured number below the stated range.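

In this assay, amino in place of hydrogen on an aromatic carbon gives a 1.2-fold lower number from compound 3 to compound 4 (0.08 log units; within the scatter), so on the core of compound 3 the two values cannot be told apart. Set against the earlier step, the change does not carry over from one core to the other with a single size, and a step read on one core is a poor guide to the step on the other: the same change on two cores in this assay, a 5.5-fold higher number (0.74 log units; beyond the scatter) from compound 1 to compound 2 and a 1.2-fold lower number (0.08 log units; within the scatter) from compound 3 to compound 4, 6.6-fold (0.82 log units) apart, beyond the scatter of two such steps

These two pairs show only that the size of the step depends on the core in this series; they do not show which feature of the differently joined cores is responsible, nor whether the result holds in any other cell line or read-out.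

From the compounds shown here alone, whether a methylamino or dimethylamino group on the same aromatic carbon would follow the pattern of compound 2 or that of compound 4 remains open. Also open, going by these compounds, is how either core would respond if a hydroxymethyl group or a longer chain such as chloroethyl stood in place of chloromethyl on the benzyl group, since all four compounds carry that same chloromethyl group.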